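Swapping a Methyl Ring for a Chloro-Trifluoromethyl Ring

A few compounds are considered here, and "the series" means these few. Any claim that something is new, unique, unknown or untested is made for them only; others in the source may bear on it.

Three compounds share one core and differ only in the aromatic ring on a double-bonded chain carbon. In a functional assay on MCF7 cells (Homo sapiens) for inhibition (a higher number here means a weaker inhibitor, a lower number a stronger inhibitor), compound 1 `CC/C(=C(/c1ccc(/C=C/C(=O)O)cc1)c1cc2ccccc2[nH]1)c1cccc(C)c1` gives 140 nM, the highest of the three numbers. Compound 2 `CC/C(=C(/c1ccc(/C=C/C(=O)O)cc1)c1cc2ccccc2[nH]1)c1ccc(C(F)(F)F)cc1` gives 139 nM, and the step of a 1.0-fold lower number from compound 1 to compound 2 (0.00 log units; within the scatter) stays within the scatter. Compound 3 `CC/C(=C(/c1ccc(/C=C/C(=O)O)cc1)c1cc2ccccc2[nH]1)c1ccc(Cl)cc1C#N` gives 14 nM, reached by a 10-fold lower number from compound 1 to compound 3 (1.00 log units; beyond the scatter) and by a 9.9-fold lower number from compound 2 to compound 3 (1.00 log units; beyond the scatter). Compound 4 `CC/C(=C(/c1ccc(/C=C/C(=O)O)cc1)c1cc2ccccc2[nH]1)c1ccc(Cl)cc1C(F)(F)F` carries the change (4-chloro-2-(trifluoromethyl)phenyl in place of 3-methylphenyl on a double-bonded chain carbon bound to a double-bonded chain carbon and a saturated chain carbon). The step from compound 1 to compound 3 bears most closely on it: the 4-chloro-2-cyanophenyl of compound 3 shares its chlorine with the 4-chloro-2-(trifluoromethyl)phenyl of compound 4, while the step from compound 1 to compound 2 shows a trifluoromethyl alone changing nothing beyond the scatter. A gain smaller than that of compound 3 is therefore expected, namely a 3.5-fold lower number from compound 1 to compound 4 (0.54 log units; beyond the scatter). Compound 4 is estimated at 40 nM, within 15 nM to 120 nM.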

Compound 4, half-maximal inhibitory concentration: 4 nM
Compound 4: middle estimate off by 10-fold (1.00 log units), on the high side; measured number outside the range, below it.
By their numbers in this assay, from the lowest: compound 4; then compound 3; then compounds 2 and 1 (each within the scatter of the next).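

In this assay the 4-chloro-2-(trifluoromethyl)phenyl ring gives a 35-fold lower number from compound 1 to compound 4 (1.54 log units; beyond the scatter) and a 35-fold lower number from compound 2 to compound 4 (1.54 log units; beyond the scatter) so trifluoromethyl, which left the number unchanged within the scatter in compound 2, here accompanies a large gain once chlorine is also on the ring. Trifluoromethyl in place of cyano on an aromatic carbon gives a 3.5-fold lower number from compound 3 to compound 4 (0.54 log units; beyond the scatter) so the nitrile of compound 3 is not required for strong inhibition. No measurement here explains these differences.

The compounds shown leave open how much of the gain belongs to chlorine alone. They also leave open whether bromine or a methoxy group in place of that chlorine would keep it.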